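The source may report more compounds than this note shows. Statements on the series, on what has been measured and on what is new or still open speak of the compounds shown alone.

Measured so far in an ADME assay on HEK293 cells (Homo sapiens) for cytotoxicity, read by reporter gene assay and resazurin assay, with a stated time of 48 h; a lower number here means that less compound is tolerated, a higher number that more compound is tolerated:
Compound 1 `O=C(Nc1ccc(Sc2nc3ccccc3s2)c(Cl)c1)c1cccc(Br)c1O`: 64000 nM
Compound 2 `COc1c(Br)cc(Br)cc1C(=O)Nc1ccc(Sc2nc3ccccc3s2)c(Cl)c1`: > 100000 nM, a limit
Compound 3 `COc1ccccc1C(=O)Nc1ccc(Sc2nc3ccccc3s2)c(Cl)c1`: > 100000 nM, a limit

Compound 3 has no exact number, only a limit of the assay. It stands with compound 2 at the limit of > 100000 nM in this assay, at which 2 of the 3 values shown sit.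

Compound 4 `O=C(Nc1ccc(Sc2nc3ccccc3s2)c(Cl)c1)c1ccccc1O` comes from compound 3 through a single change, (hydrogen in place of methyl on an oxygen on an aromatic ring), which turns methoxy into hydroxy. Among the compounds with values here, two measured steps bear on this change, and both also involve bromine. The first, an at least 1.5-fold higher number from compound 1 to compound 3 (0.19 log units; that floor lies within the scatter), runs from hydroxy to methoxy and loses the bromine. The second, an at least 1.5-fold higher number from compound 1 to compound 2 (0.19 log units; that floor lies within the scatter), also runs from hydroxy to methoxy but adds a bromine. Both give only a floor that lies within the scatter, so neither fixes a size. The remaining step, a step that the two limits leave unreadable from compound 2 to compound 3, has no readable size.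

Within the data shown here, compound 1 is the only measured compound with a hydroxy group, and it is also the only one with an exact number in this assay. On the strength of compound 1 at 64000 nM, a modest move towards a lower number is expected. Another limit remains possible for compound 4. The expected step is an at least 1.5-fold lower number from compound 3 to compound 4 (0.18 log units; that floor lies within the scatter). Compound 4 is estimated at 65000 nM, with an expected range of 25000 nM to 100000 nM.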

Compound 4, half-maximal cytotoxic concentration: 64000 nM
Compound 4: the middle estimate sits 1.0-fold (0.01 log units) above what was measured; the range from low to high includes it.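

In this assay, hydrogen in place of methyl on an oxygen on an aromatic ring gives an at least 1.5-fold lower number from compound 3 to compound 4 (0.19 log units; that floor lies within the scatter), and the group change on the carbonyl carbon gives an at least 1.5-fold lower number from compound 2 to compound 4 (0.19 log units; that floor lies within the scatter); neither step fixes a size. Hydrogen in place of bromo on an aromatic carbon gives no change at the digits printed from compound 1 to compound 4 (within the scatter), so, with the hydroxy group kept, this is the first exact comparison in the set and the bromo group makes no difference beyond the scatter. Compound 1 and compound 4, which carry the hydroxy group, now both have exact numbers, whereas compound 2 and compound 3, which carry methoxy, both rest on a limit, and this grouping is only as firm as floors within the scatter allow: the limit of > 100000 nM in this assay, at which 2 of the 4 values shown sit.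

The compounds shown leave open how far methoxy really lies from hydroxy, since a limit gives no exact number to measure that step against. They also leave open what an amine or a carboxylic acid in place of the hydroxy group, or a longer chain such as ethoxy, would do at this position.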